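Changing the Ring on the Double-Bonded Carbon

A few compounds are considered here, and "the series" means these few. Any claim that something is new, unique, unknown or untested is made for them only; others in the source may bear on it.

Of the compounds shown here, three sharing one core have been measured in a functional assay on NCI-H460 cells (Homo sapiens) for cytotoxicity, read by MTT assay, with a stated time of 72 h; on this read-out lower numbers stand for stronger inhibition and higher numbers for weaker inhibition. Compound 1 `CN(C)CCn1cnnc1-c1cc(Oc2ccc(NC(=O)N/N=C/c3ccc(Cl)cc3Cl)cc2F)ccn1` gives 130 nM. Compound 2 `CN(C)CCn1cnnc1-c1cc(Oc2ccc(NC(=O)N/N=C/c3ccc(F)cc3F)cc2F)ccn1` gives 1930 nM, and compound 3 `COc1cc(/C=N/NC(=O)Nc2ccc(Oc3ccnc(-c4nncn4CCN(C)C)c3)c(F)c2)cc(OC)c1OC` gives 2770 nM. Compound 3 thus carries the highest number of the three: it sits close to compound 2, the step of a 1.4-fold higher number from compound 2 to compound 3 (0.16 log units; within the scatter) lying within the scatter, but far from compound 1, as the step of a 21-fold higher number from compound 1 to compound 3 (1.33 log units; beyond the scatter) shows.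

Compound 4 `CN(C)CCn1cnnc1-c1cc(Oc2ccc(NC(=O)N/N=C/c3ccc(Cl)cc3)cc2F)ccn1` differs from compound 3 in one place: 4-chlorophenyl in place of 3,4,5-trimethoxyphenyl on a carbon with a double bond to nitrogen. For the measured compounds named here, two measured steps bear on this. Replacing 2,4-dichlorophenyl with 2,4-difluorophenyl gave a 15-fold higher number from compound 1 to compound 2 (1.17 log units; beyond the scatter), and replacing it with 3,4,5-trimethoxyphenyl gave a 21-fold higher number from compound 1 to compound 3 (1.33 log units; beyond the scatter); each move away from the chlorine-bearing ring weakened the compound greatly. Compound 4 keeps one chlorine on its ring but lacks the second, so the move from compound 3 is expected to lower the number, though probably not all the way back to where compound 1 stands. The step of a 5.5-fold lower number from compound 3 to compound 4 (0.74 log units; beyond the scatter) is therefore expected. For compound 4 the estimate is 500 nM, with a range from 150 nM to 2000 nM.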

Compound 4, half-maximal inhibitory concentration: 320 nM
The estimate for compound 4 lay 1.6-fold (0.19 log units) above the measured number; the range from low to high includes it.
By their numbers in this assay, from the lowest: compound 1; then compound 4; then compounds 2 and 3 (each within the scatter of the next).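

In this assay, a single chlorine on the ring is enough to recover most of the lost ground: 4-chlorophenyl gives an 8.7-fold lower number from compound 3 to compound 4 (0.94 log units; beyond the scatter), and against the 2,4-difluorophenyl ring it gives a 6.0-fold lower number from compound 2 to compound 4 (0.78 log units; beyond the scatter). The earlier compounds shown here swapped one whole ring for another, whereas compound 1 and compound 4 differ by one atom, and hydrogen in place of chloro on an aromatic carbon gives a 2.5-fold higher number from compound 1 to compound 4 (0.39 log units; beyond the scatter), so the second chlorine of the 2,4-dichlorophenyl ring still counts, although its loss costs far less than either of the earlier ring changes. Across these four compounds, the two rings bearing chlorine give lower numbers than the rings bearing fluorine or methoxy groups, and no measurement at hand explains why.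

The compounds shown leave open whether chlorine itself is what matters, or whether a plain phenyl ring, or a ring with bromine or a methyl group where 4-chlorophenyl has its chlorine, would give a similar number. They also leave open how a ring with a single fluorine, or one with an amine or a carboxylic acid, would behave at this position.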